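The source may report more compounds than this note shows. Statements on the series, on what has been measured and on what is new or still open speak of the compounds shown alone.

Measured in a functional assay on KB-VIN10 cells (Homo sapiens) for inhibition, with a stated time of 72 h; on this read-out higher numbers stand for weaker inhibition and lower numbers for stronger inhibition:
compound 1 `COc1ccc(S(=O)(=O)N2CCc3cccc(-c4ccc(N)cc4)c32)cc1`: 262 nM
compound 2 `COc1ccc(S(=O)(=O)N2CCc3cccc(-c4ccc(F)c(F)c4)c32)cc1`: 46 nM
compound 3 `COc1ccc(S(=O)(=O)N2CCc3cccc(-c4cc(OC)c(OC)c(OC)c4)c32)cc1`: 4670 nM

Compound 2, at 46 nM, has the lowest number of the three. Compound 4 `COc1ccc(S(=O)(=O)N2CCc3cccc(-c4ccncc4)c32)cc1` has not yet been measured and differs from compound 2 by one group on an aromatic carbon: pyridin-4-yl in place of 3,4-difluorophenyl on an aromatic carbon.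

Going by the values given here, the only measured step at this carbon is a 5.7-fold lower number from compound 1 to compound 2 (0.76 log units; beyond the scatter). It is modest in size and also involves 3,4-difluorophenyl. Among the compounds with values here, no measured compound carries pyridin-4-yl, so this step is a guide to size only. Both measured compounds without 3,4-difluorophenyl have higher numbers: compound 1 at 262 nM and compound 3 at 4670 nM. With so few compounds, this is weak evidence for direction, and a result within the scatter of compound 2 remains possible.

A modest rise is expected, of similar size to the step at this carbon: a 3.3-fold higher number from compound 2 to compound 4 (0.51 log units; beyond the scatter). The estimate for compound 4 is 150 nM, with an expected range of 35 nM to 700 nM.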

Compound 4, half-maximal inhibitory concentration: 106 nM
Compound 4: the middle estimate sits 1.4-fold (0.15 log units) above what was measured; low and high end bracket the measured number.
By their numbers in this assay, from the lowest: compound 2; then compound 4; then compound 1; then compound 3.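

A six-membered aromatic ring with a hetero atom can stand on this aromatic carbon, and the series in this assay now has a result for a substituent that is not a phenyl ring. Pyridin-4-yl costs only a modest amount against 3,4-difluorophenyl, with a 2.3-fold higher number from compound 2 to compound 4 (0.36 log units; beyond the scatter), and gains a modest amount against 4-aminophenyl, with a 2.5-fold lower number from compound 1 to compound 4 (0.39 log units; beyond the scatter), so the position separates these three groups in modest steps rather than large ones. No measurement on hand accounts for this order.

The compounds shown leave open how much of the standing of compound 2 belongs to the two fluorines, since unsubstituted phenyl and 4-fluorophenyl would be needed to divide it. Going by these compounds, whether the place of the ring nitrogen matters also remains open, and pyridin-3-yl would address that.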